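Adding a fluoro group to a trimethoxy chalcone scaffold

The source may report more compounds than this note shows. Statements on the series, on what has been measured and on what is new or still open speak of the compounds shown alone.

Measured compounds:
compound 1 `COc1cc(O)c(C(=O)/C=C/c2ccc(F)cc2)c(OC)c1`: "not active" (no number reported)
compound 2 `COc1cc(OC)c(C(=O)/C=C/c2ccccc2SC)c(OC)c1`: 3%
compound 3 `COc1cc(OC)c(C(=O)/C=C/c2ccccc2)c(OC)c1`: 4.5%

In a functional assay on NCI-H727 cells (Homo sapiens), read by fluorescence and BrdU incorporation, with a stated time of 48 h, tested at 25 uM (a lower number here means a stronger effect, a higher number a weaker effect of the compound at the concentration tested), compound 3 gives 4.5%, the higher of the two numbers, yet a number 1.5 percentage points higher from compound 2 to compound 3 (within the scatter). Compound 1 is reported only as not active, without a number. Compound 4 `COc1cc(OC)c(C(=O)/C=C/c2ccc(F)cc2)c(OC)c1` differs from compound 3 by fluoro in place of hydrogen on an aromatic carbon. Among the compounds with values here, no measured step bears on this change directly; the single step known, a number 1.5 percentage points higher from compound 2 to compound 3 (within the scatter), concerns a different group and lay within the scatter. Compound 4 is therefore expected to give 7% (range 2% to 30%), an estimated step of a number 2.5 percentage points higher from compound 3 to compound 4 (within the scatter) that stays within the scatter.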

Compound 4, a percentage reported as activity, at one concentration (the size of the read-out at that concentration, not a potency): 4.5%
Compound 4: the middle estimate sits 2.5 percentage points above what was measured; measured number inside the range.
By their numbers in this assay, from the lowest: compounds 2, 3 and 4 (each within the scatter of the next).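

In this assay, within the data shown here, placing fluoro on the aromatic carbon para to a large group gives no change at the digits printed from compound 3 to compound 4 (within the scatter) and is the first look at this change on the shared core. The wider swap of 2-(methylsulfanyl)phenyl for 4-fluorophenyl gives a number 1.5 percentage points higher from compound 2 to compound 4 (within the scatter) and so does not separate these two groups either. No available evidence accounts for this result. On these data alone, whether an amine or a carboxylic acid at this same position would shift the read-out remains open. Compound 1 gives "not active" (no number reported) and so offers no number to set against compound 4.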